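The source may hold more compounds than are shown below. What is called first, only, known or untested is meant among the compounds shown, and "the series" means these compounds.

In an ADME assay on a cell-free system (plasma, Mus musculus) for protein binding, read by LC-MS, using equilibrium dialysis, with a stated time of 4 h (a lower number here means a smaller unbound share, a higher number a larger unbound share of the compound), compound 1 `CCCOc1ccc(C(=O)Nc2cc(OC(F)(F)F)ccc2-n2cncn2)cc1OC` gives 0.019, and compound 2 `COc1cc(C(=O)Nc2cc(OC(F)(F)F)ccc2-n2cncn2)ccc1OC(C)C` gives 0.063, the higher of the two numbers. Compound 3 `COc1cc(C(=O)Nc2cc(OC(F)(F)F)ccc2-n2cncn2)ccc1OC1CC1` is the next structure, and it differs from compound 2 as follows: cyclopropyl in place of isopropyl on an oxygen on an aromatic ring. Among the compounds with values here, only one measured step bears on this change, a 3.3-fold higher number from compound 1 to compound 2 (0.52 log units; beyond the scatter). Within the data shown here, that modest step, beyond the scatter, also swapped one group for another on an oxygen on an aromatic ring, but no measured compound carries a cyclopropyl. The expected step is therefore small, a 1.1-fold lower number from compound 2 to compound 3 (0.02 log units; within the scatter), with no shift beyond the scatter expected in this assay. For compound 3 the estimated value is 0.06, with an expected range from 0.03 to 0.12.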

Compound 3, unbound fraction: 0.039
Compound 3: middle estimate off by 1.5-fold (0.19 log units), on the high side; the range from low to high includes it.
By their numbers in this assay, from the lowest: compound 1; then compounds 3 and 2 (each within the scatter of the next).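

The ring closure from isopropyl to cyclopropyl on this oxygen makes no clear difference in this assay (a 1.6-fold lower number from compound 2 to compound 3 (0.21 log units; within the scatter)). The branched isopropyl is thus not alone in standing apart from the propyl of compound 1, as cyclopropyl does too (a 2.1-fold higher number from compound 1 to compound 3 (0.31 log units; beyond the scatter)), though that gap only just clears the scatter. No measurement here explains these numbers. Still open, on these data alone, is whether a longer chain or a chain ending in an amine on this oxygen would read closer to compound 1 or to compound 2 and compound 3.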